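Aryl swap on the ring amine nitrogen: expectation for compound 3

This account rests on a few compounds, and the source may have more. Where it says the series, first, only, none or still open, it means among the compounds named here.

The series shares one core, carried here by compound 1 `Cc1ccc(N2CCN(C(=S)N/N=C3\C(=O)Nc4ccc(Cl)cc43)CC2)cc1` and compound 2 `O=C1Nc2ccc(Cl)cc2/C1=N/NC(=S)N1CCN(c2ccccc2Cl)CC1`. In a functional assay on MCF7 cells (Homo sapiens) for inhibition, read by MTT assay, with a stated time of 72 h (on this read-out lower numbers stand for stronger inhibition and higher numbers for weaker inhibition), compound 1 gives 17100 nM, and compound 2 gives 11700 nM. Compound 2 thus stands at the lower end of the two numbers shown, but the step of a 1.5-fold lower number from compound 1 to compound 2 (0.16 log units; within the scatter) does not separate the two compounds, and the one structural change between them, 2-chlorophenyl in place of 4-methylphenyl on the amine nitrogen in the ring, left this assay unmoved beyond the scatter.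

Compound 3 `O=C1Nc2ccc(Cl)cc2/C1=N/NC(=S)N1CCN(c2ccc([N+](=O)[O-])cc2)CC1` is not yet measured. Its change from compound 2 is 4-nitrophenyl in place of 2-chlorophenyl on an amine nitrogen in a ring. This is the same position that was varied in the step from compound 1 to compound 2; that single bearing step was within the scatter. Among the measured compounds shown here, with only one relevant step, and that one flat, no movement beyond the scatter is expected in this assay for compound 3 in either direction. Compound 3 is therefore expected to give 12000 nM, with a range from 4000 nM to 36000 nM. The expected step from compound 2 is a 1.0-fold higher number from compound 2 to compound 3 (0.01 log units; within the scatter).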

Compound 3, half-maximal inhibitory concentration: 20900 nM
Compound 3: the middle estimate sits 1.7-fold (0.24 log units) below what was measured; the range from low to high includes it.
By their numbers in this assay, from the lowest: compounds 2, 1 and 3 (each within the scatter of the next).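

On the amine nitrogen in the ring, the series now spans three aryl groups, and in this assay the change to 4-nitrophenyl gives a 1.8-fold higher number from compound 2 to compound 3 (0.25 log units; within the scatter), while nitro in place of methyl on an aromatic carbon gives a 1.2-fold higher number from compound 1 to compound 3 (0.09 log units; within the scatter). All three pairs at this position now lie within the scatter, so 4-methylphenyl, 2-chlorophenyl and 4-nitrophenyl cannot be told apart on this read-out, even though the entering 4-nitrophenyl carries 2 hydrogen-bond acceptors and the 2-chlorophenyl carries 0. No measured property is available that bears on this flat result.

All three compounds keep a substituted phenyl group on this nitrogen, which leaves open whether a longer alkyl chain, a chain ending in an amine, or a phenyl group bearing a carboxylic acid would shift the number beyond the scatter. These compounds also leave open whether the same flat picture would hold at any other place on the shared core, where all three are identical.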